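Removing a methoxy group: will compound 4 stay inert?

The compounds below may be only part of what the source reports. "The series", "measured", "known", "first", "only" and "open" are said of these compounds alone.

Three compounds with a shared core were tested in a functional assay on CCRF-CEM cells (Homo sapiens) for cytotoxicity, read by MTT assay, with a stated time of 72 h (a lower number here means that less compound is tolerated, a higher number that more compound is tolerated), and none of them reached a measurable value. Compound 1 `C[Se]c1nc(N)c2ccccc2n1` gives only a limit, > 100000 nM. Compound 2 `COc1ccc(CNc2nc(SC)nc3ccccc23)cc1`, which carries a methoxy group on its pendant ring, likewise gives a limit, > 100000 nM. Compound 3 `CSc1ccc(CNc2nc([SeH])nc3ccccc23)cc1` also gives a limit, > 100000 nM. Compound 2 therefore stands exactly where the whole set stands, which is the limit of > 100000 nM in this assay, at which 3 of the 3 values shown sit.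

Compound 4 `CSc1nc(NCc2ccccc2)c2ccccc2n1` is not yet measured. It differs from compound 2 by a single change: hydrogen in place of methoxy on an aromatic carbon. Among the compounds with values here, because every measured value sits at the limit of > 100000 nM in this assay, at which 3 of the 3 values shown sit, there is no step between measured compounds to guide the size of this change, and the expectation is that no movement beyond the usual scatter will appear, so the expected step from compound 2 to compound 4 in this assay is a number no higher from compound 2 to compound 4 (the limit leaves the size open). The estimate for compound 4 in this assay is 100000 nM, expected to fall between 30000 nM and 300000 nM.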

Compound 4, concentration lethal to 50% of the cells: > 100000 nM
Compound 4 was reported as a limit (the forecaster's own chance of this, stated with the estimate: 75%); the middle value lies on the limit itself.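

Compound 2 and compound 4 are both reported only as limits, so swapping methoxy for hydrogen gives no step that can be read: the limit of > 100000 nM in this assay, at which 4 of the 4 values shown sit.

The compounds shown leave open whether any change to the shared core would give a measurable value at all.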